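The compounds below may be only part of what the source reports. "The series", "measured", "known", "first", "only" and "open" are said of these compounds alone.

Three compounds share one core and differ only in the group on the outer benzene ring. Compound 1 `CCCc1ccc(C(=O)Nc2cccc(NC(=O)COc3ccc4c(=O)ccoc4c3)c2)cc1` carries a propyl group there; in an assay on isolated protein for inhibition of Rho-associated protein kinase 2 (Homo sapiens), read by scintillation counting, radiometric assay and 33P incorporation, with a stated time of 40 min, in the presence of a further agent that is not named here (on this read-out higher numbers stand for weaker inhibition and lower numbers for stronger inhibition), compound 1 gives 14 nM. Compound 2 `O=C(COc1ccc2c(=O)ccoc2c1)Nc1cccc(NC(=O)c2ccc(F)cc2)c1` carries a fluoro group instead, and in this assay compound 2 gives 54 nM; the step of a 3.9-fold higher number from compound 1 to compound 2 (0.59 log units; beyond the scatter) is modest but real. Compound 3 `CCOc1ccc(C(=O)Nc2cccc(NC(=O)COc3ccc4c(=O)ccoc4c3)c2)cc1` carries an ethoxy group, and in this assay compound 3 gives 9 nM, the lowest of the three numbers; a 1.6-fold lower number from compound 1 to compound 3 (0.19 log units; within the scatter) is too small to count, while a 6.0-fold lower number from compound 2 to compound 3 (0.78 log units; beyond the scatter) is clear.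

Compound 4 `COC(=O)c1ccc(C(=O)Nc2cccc(NC(=O)COc3ccc4c(=O)ccoc4c3)c2)cc1` is the next step from compound 3: methoxycarbonyl in place of ethoxy on an aromatic carbon, on an aromatic carbon of a six-membered aromatic ring of carbon only, para to a large group. Going by the values given here, no measured step exchanges an ethoxy group for a methoxycarbonyl group, so the two steps seen so far only set the width of the possible outcome. For compound 4 the step of a 2.8-fold higher number from compound 3 to compound 4 (0.44 log units; beyond the scatter) is expected, with a wide range. Compound 4 is estimated at 25 nM, between 8 nM and 80 nM.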

Compound 4, half-maximal inhibitory concentration: 29 nM
For compound 4 the middle estimate is 1.2-fold (0.06 log units) below the measured one; the range from low to high includes it.
By their numbers in this assay, from the lowest: compounds 3 and 1 (each within the scatter of the next); then compounds 4 and 2 (each within the scatter of the next).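

Putting methoxycarbonyl in place of ethoxy adds a double bond and an oxygen at this position, and in this assay it weakens inhibition (a 3.2-fold higher number from compound 3 to compound 4 (0.51 log units; beyond the scatter)), with the same direction against propyl (a 2.1-fold higher number from compound 1 to compound 4 (0.32 log units; beyond the scatter)). Against fluoro the change cannot be told from scatter (a 1.9-fold lower number from compound 2 to compound 4 (0.27 log units; within the scatter)), so among these four compounds the groups fall into two tiers: ethoxy and propyl in compounds 3 and 1, and methoxycarbonyl and fluoro in compounds 4 and 2. Nothing available here explains this split.

Going by these compounds, it remains open how a carboxylic acid, an amine or a chain longer than propyl would behave at this position. These four compounds also cannot show whether the two tiers would hold for further groups.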